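The source may hold more compounds than are shown below. What is called first, only, known or untested is meant among the compounds shown, and "the series" means these compounds.

Series values in an ADME assay on L02 cells (Homo sapiens) for cytotoxicity, read by MTT assay, with a stated time of 24 h; on this read-out lower numbers stand for higher toxicity in this test and higher numbers for lower toxicity in this test:

- compound 1 `CC1(C)[C@H]2CC[C@]1(C)N(Cc1cn(-c3ccc(C#N)cc3)nn1)C(=O)C2` gives 15700 nM
- compound 2 `CC1(C)[C@H]2CC[C@]1(C)N(Cc1cn(-c3ccccc3F)nn1)C(=O)C2` gives 13300 nM
- compound 3 `CC1(C)[C@H]2CC[C@]1(C)N(Cc1cn(-c3ccccc3Cl)nn1)C(=O)C2` gives 20100 nM

Compound 3, at 20100 nM, cannot be separated from the other two. The measured steps are a 1.3-fold higher number from compound 1 to compound 3 (0.11 log units; within the scatter) and a 1.5-fold higher number from compound 2 to compound 3 (0.18 log units; within the scatter), and both stay inside the scatter.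

Compound 4 `CC1(C)[C@H]2CC[C@]1(C)N(Cc1cn(-c3cccc(Cl)c3)nn1)C(=O)C2` is an isomer of compound 3 with the same atoms joined differently: 3-chlorophenyl in place of 2-chlorophenyl on an aromatic nitrogen. It carries 3-chlorophenyl in place of 2-chlorophenyl on an aromatic nitrogen.

Among the compounds with values here, no measured pair moves a chlorine around the phenyl ring, so the evidence is indirect. Changing the aryl group from compound 1 gave a 1.2-fold lower number from compound 1 to compound 2 (0.07 log units; within the scatter), and the halogen swap gave a 1.5-fold higher number from compound 2 to compound 3 (0.18 log units; within the scatter). Neither left the scatter, so the three compounds show little response to changes on this phenyl ring.

The expected change is small, a 1.1-fold lower number from compound 3 to compound 4 (0.05 log units; within the scatter), with no step beyond the scatter anticipated.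

For compound 4 the estimated value is 18000 nM, with an expected range from 10000 nM to 32000 nM.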

Compound 4, half-maximal cytotoxic concentration: 8510 nM
Compound 4: the middle estimate sits 2.1-fold (0.33 log units) above what was measured, and the stated range ends above it.
By their numbers in this assay, from the lowest: compounds 4, 2, 1 and 3 (each within the scatter of the next, the first and the last beyond it).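

In this assay, within the data shown here, the shift from 2-chlorophenyl to 3-chlorophenyl gives a 2.4-fold lower number from compound 3 to compound 4 (0.37 log units; beyond the scatter), the first step to leave the scatter, so this phenyl ring is not as unresponsive as the earlier compounds suggested, although the step is modest. The other new steps, a 1.6-fold lower number from compound 2 to compound 4 (0.19 log units; within the scatter) and a 1.8-fold lower number from compound 1 to compound 4 (0.27 log units; within the scatter), stay within the scatter, so compound 4 separates only from compound 3. The data available offer no explanation for the difference between the two chlorophenyl isomers.

Going by these compounds, it remains open whether an amine or a carboxylic acid in place of the chlorine would shift the number as far. On these data alone, the reading of an unsubstituted phenyl on the same aromatic nitrogen also remains open.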